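The source may report more compounds than this note shows. Statements on the series, on what has been measured and on what is new or still open speak of the compounds shown alone.

Measured so far:
compound 1 `CC1=C(C(=O)OC(C)C)[C@@H](c2ccco2)N/C(=N/C#N)N1` — 15.1 nM
compound 2 `CC1=C(C(=O)OC(C)C)C(c2ccsc2)N/C(=N/C#N)N1` — 647 nM
compound 3 `CCOC(=O)C1=C(C)N/C(=N\C#N)NC1c1ccsc1` — 461 nM

Compound 2 gives the highest number of the three in an assay on HEK293 cells for displacement of a labelled ligand from adenosine receptor A2b (Homo sapiens), with a stated time of 30 min; on this read-out lower numbers stand for stronger inhibition and higher numbers for weaker inhibition. For the measured compounds named here, its nearest neighbour on the numbers is compound 3, which in this assay gives 461 nM; the only single-place step measured in this set is a 1.4-fold lower number from compound 2 to compound 3 (0.15 log units; within the scatter), and it concerns the ester, not the ring. Going by the values given here, compound 1 differs from compound 2 in more than one place, so no step is computed for that pair; its two values alone show a large gap.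

Compound 4 `CC1=C(C(=O)OC(C)C)C(c2ccoc2)N/C(=N/C#N)N1` is not yet measured. It differs from compound 2 by furan-3-yl in place of thiophen-3-yl on a saturated ring carbon. Among the compounds with values here, no measured step covers this exchange. The ester step from compound 2 to compound 3 says nothing about it, and the gap to compound 1 cannot be assigned to the ring alone. The expectation therefore rests mainly on the number of compound 2, with the value of compound 1 pulling it somewhat toward lower numbers.

For compound 4 the expected value in this assay is 150 nM, in the range 30 nM to 700 nM, which is an expected step of a 4.3-fold lower number from compound 2 to compound 4 (0.63 log units; beyond the scatter).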

Compound 4, inhibition constant: 59.4 nM
Compound 4: middle estimate off by 2.5-fold (0.40 log units), on the high side; the measured number falls inside the stated range.
By their numbers in this assay, from the lowest: compound 1; then compound 4; then compounds 3 and 2 (each within the scatter of the next).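

In this assay, for the compounds shown here, the exchange of thiophen-3-yl for furan-3-yl on the saturated ring carbon gives an 11-fold lower number from compound 2 to compound 4 (1.04 log units; beyond the scatter), whereas the ester change gave only a 1.4-fold lower number from compound 2 to compound 3 (0.15 log units; within the scatter), so this position is the first place where a single change moves the number beyond the scatter. The leaving and entering groups have the same counts of heavy atoms, hydrogen-bond donors and hydrogen-bond acceptors, and differ in the ring hetero atom, sulfur against oxygen, so an exchange this small is enough to produce a large step. Nothing available explains the size of this step.

On these data alone, whether the same exchange gives a step of similar size with the ethyl ester of compound 3 remains open. As far as these compounds go, how a phenyl or a pyridin-3-yl group on this saturated ring carbon would compare with furan-3-yl is also open.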